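Adding a Hydroxy Group to Compound 3

This account rests on a few compounds, and the source may have more. Where it says the series, first, only, none or still open, it means among the compounds named here.

Compound 1 `CCC(c1ccc(O)c(OC)c1)c1cccc(O)c1O`, compound 2 `CCOc1cccc(C(CC)c2ccc(O)c(OC)c2)c1O` and compound 3 `CCC(c1ccc(O)c(OC)c1)c1ccccc1O` share one core. In a functional assay for inhibition, with a stated time of 30 h, tested at 100 ug/mL (on this read-out higher numbers stand for more inhibition at the one concentration tested (going by the name of the read-out) and lower numbers for less inhibition), compound 1 gives 97%, compound 2 gives 97% and compound 3 gives 97%, so compound 3 stands level with both, with no change at the digits printed from compound 1 to compound 3 (within the scatter) and no change at the digits printed from compound 2 to compound 3 (within the scatter). Compound 4 `CCC(c1ccc(O)c(OC)c1)c1ccc(O)cc1O` differs from compound 3 by hydroxy in place of hydrogen on an aromatic carbon. The measured step that bears on this change runs the opposite way, removing a hydroxy group, and it showed no change at the digits printed from compound 1 to compound 3 (within the scatter). Because no change at the digits printed from compound 1 to compound 3 (within the scatter) stayed within the scatter, the step is expected to be a number 1 percentage points lower from compound 3 to compound 4 (within the scatter), with no movement beyond the scatter. Compound 4 is therefore estimated to give 96%, within a range from 88% to 100%.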

Compound 4, a percentage reported as inhibition, at one concentration (the size of the read-out at that concentration, not a potency): 97%
Estimate against measurement, compound 4: 1 percentage points below; the range from low to high includes it.
By their numbers in this assay, from the lowest: compounds 1, 2, 3 and 4 (each within the scatter of the next).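

In this assay there was no change at the digits printed from compound 3 to compound 4 (within the scatter) when hydroxy took the place of hydrogen on an aromatic carbon, meta to a hydroxy group and para to a large group. Within the data shown here, the earlier compounds carried their added oxygen groups elsewhere on this ring, so this is the first sign that a hydroxy group at this position also leaves the reading in place. No measurement shown explains this result. As far as these compounds go, whether an amine, a carboxylic acid or a longer chain at this position would hold the reading remains open. Potency also remains open, since the read-out reports inhibition at one concentration only.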